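Swapping the pyrazole of compound 2 for a thiazole

The source may hold more compounds than are shown below. What is called first, only, known or untested is meant among the compounds shown, and "the series" means these compounds.

Measured in an ADME assay on microsomes from liver (Homo sapiens) for metabolic stability; a higher number here means faster removal of the compound, a lower number slower removal:
- Compound 1 `Cc1ccc([C@H](C)NC(=O)Cn2nnc3ccccc3c2=O)c(F)c1`: 28 mL/min/kg
- Compound 2 `C[C@H](NC(=O)Cn1nnc2ccccc2c1=O)c1ccn(C)n1`: 12 mL/min/kg

For the measured compounds named here, of the two measured compounds, compound 2 stands lowest, at 12 mL/min/kg, while its only neighbour, compound 1, gives 28 mL/min/kg. The next compound, compound 3 `C[C@H](NC(=O)Cn1nnc2ccccc2c1=O)c1nccs1`, keeps everything in compound 2 except one group, which changes as follows: 1,3-thiazol-2-yl in place of 1-methyl-1H-pyrazol-3-yl on a saturated chain carbon bound to an amide-type nitrogen and a saturated chain carbon. The swap puts 1,3-thiazol-2-yl in place of 1-methyl-1H-pyrazol-3-yl on a saturated chain carbon bound to an amide-type nitrogen and a saturated chain carbon.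

Going by the values given here, only one measured step bears on this. It changed the group at the same place, replacing 2-fluoro-4-methylphenyl with 1-methyl-1H-pyrazol-3-yl, and it was modest: a 2.3-fold lower number from compound 1 to compound 2 (0.37 log units; beyond the scatter). Among the compounds with values here, no measurement yet compares the two five-membered rings directly, so that step gives only a rough sense of how much this place can move this assay. A small rise, probably not beyond the scatter, is expected. The expected change is a 1.3-fold higher number from compound 2 to compound 3 (0.12 log units; within the scatter). For compound 3 the estimated clearance is 16 mL/min/kg, with an expected range from 8 mL/min/kg to 30 mL/min/kg.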

Compound 3, clearance: < 9.9 mL/min/kg
Compound 3 gave a limit, no number; the forecaster's own chance of this, stated with the estimate: 3%; at least 1.6-fold (0.20 log units) between middle value and limit.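

In this assay compound 3 gives < 9.9 mL/min/kg, which is a limit of the assay and not a number. Between the two five-membered rings the comparison reads an at least 1.2-fold lower number from compound 2 to compound 3 (0.08 log units; that floor lies within the scatter), so this floor does not separate 1,3-thiazol-2-yl from 1-methyl-1H-pyrazol-3-yl, and the true size of the step stays unknown: the limit of < 9.9 mL/min/kg in this assay, at which 1 of the 3 values shown sits. The comparison with the original aryl group is firmer, at an at least 2.8-fold lower number from compound 1 to compound 3 (0.45 log units; beyond the scatter), so at this place, on a saturated chain carbon bound to an amide-type nitrogen and a saturated chain carbon, both five-membered rings now give a lower number than 2-fluoro-4-methylphenyl.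

The compounds shown leave open how far under the limit the true value of compound 3 lies, and therefore whether the thiazole and pyrazole rings differ at all in this assay. They also leave open how a pyridine ring, an unsubstituted phenyl ring or a 1,3-oxazol-2-yl group would read at this place, and whether a methyl group on the thiazole ring would keep compound 3 at the limit.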